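The compounds below may be only part of what the source reports. "The series", "measured", "known", "first", "only" and "open" are said of these compounds alone.

Measured so far, from a functional assay on HT-29 cells (Homo sapiens) for inhibition, read by sulforhodamine B assay, with a stated time of 48 h; a higher number here means a weaker inhibitor of growth, a lower number a stronger inhibitor of growth:
compound 1 `CC1=CC[C@H](C(C)(C)NC(=S)N/N=C/c2ccccc2)CC1` gives 8800 nM
compound 2 `CC1=CC[C@H](C(C)(C)NC(=S)N/N=C/c2ccccc2O)CC1` gives 10900 nM
compound 3 `CC1=CC[C@H](C(C)(C)NC(=S)N/N=C/c2cccc(Cl)c2)CC1` gives 7900 nM

Compound 3 holds the lowest of the three numbers in this assay, yet the steps of a 1.1-fold lower number from compound 1 to compound 3 (0.05 log units; within the scatter) and a 1.4-fold lower number from compound 2 to compound 3 (0.14 log units; within the scatter) both sit within the scatter, so the three compounds are not separated.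

Compound 4 `CC1=CC[C@H](C(C)(C)NC(=S)N/N=C/c2cccs2)CC1` differs from compound 3 by thiophen-2-yl in place of 3-chlorophenyl on a carbon with a double bond to nitrogen. The three steps that bear on this change all alter the aryl group on the same carbon: a 1.2-fold higher number from compound 1 to compound 2 (0.09 log units; within the scatter), a 1.1-fold lower number from compound 1 to compound 3 (0.05 log units; within the scatter) and a 1.4-fold lower number from compound 2 to compound 3 (0.14 log units; within the scatter), none beyond the scatter. On that basis a step of a 1.0-fold higher number from compound 3 to compound 4 (0.01 log units; within the scatter) is expected, no direction beyond the scatter. Compound 4 is estimated at 8000 nM, with a range of 3500 nM to 18000 nM.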

Compound 4, concentration for 50% growth inhibition: 17800 nM
Estimate against measurement, compound 4: 2.2-fold (0.35 log units) below, within the range that was stated.
By their numbers in this assay, from the lowest: compounds 3, 1, 2 and 4 (each within the scatter of the next, the first and the last beyond it).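

At the carbon with a double bond to nitrogen, thiophen-2-yl gives steps beyond the scatter in this assay, which the earlier aryl changes did not: a 2.3-fold higher number from compound 3 to compound 4 (0.35 log units; beyond the scatter) and a 2.0-fold higher number from compound 1 to compound 4 (0.31 log units; beyond the scatter), both modest. The third comparison remains unresolved, a 1.6-fold higher number from compound 2 to compound 4 (0.21 log units; within the scatter). This position is therefore not wholly indifferent to the aryl group, though the steps seen are small.

No evidence bears on the reason for these steps. On these data alone, whether a 3-aminophenyl, a 3-carboxyphenyl or a pyridin-3-yl group here would give a larger step, in either direction, remains open.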